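Methyl for Methoxy at the Assay Ceiling

This account rests on a few compounds, and the source may have more. Where it says the series, first, only, none or still open, it means among the compounds named here.

Compound 1, `CNC(=O)c1ccc(Oc2cccc(NC(=S)Nc3ccc(C)c(C)c3)c2)nc1`, gives 67400 nM in a functional assay on PC-3 cells (Homo sapiens) for antiproliferative activity, read by MTT assay; on this read-out higher numbers stand for weaker inhibition and lower numbers for stronger inhibition. Compound 2, `CNC(=O)c1ccc(Oc2cccc(NC(=S)Nc3ccc(F)c(Cl)c3)c2)nc1`, gives 18400 nM. Compound 3, `CNC(=O)c1ccc(Oc2cccc(NC(=S)Nc3ccc(OC)cc3)c2)nc1`, gives only a limit of this assay, > 100000 nM.

Compound 3 thus sits at the ceiling of this assay, with no number reported. Compound 4, `CNC(=O)c1ccc(Oc2cccc(NC(=S)Nc3ccc(C)cc3)c2)nc1`, differs from it by methyl in place of methoxy on an aromatic carbon. For the measured compounds named here, no measured step swaps these two groups directly; the closest are an at least 1.4-fold higher number from compound 1 to compound 3 (0.17 log units; that floor lies within the scatter), which lies within the scatter, and an at least 5.4-fold higher number from compound 2 to compound 3 (0.73 log units; beyond the scatter). Since compound 1, which also carries methyl groups, is weak, compound 4 is expected to remain weak, with a step of an at least 1.1-fold lower number from compound 3 to compound 4 (0.04 log units; that floor lies within the scatter). The estimate for compound 4 is 90000 nM, between 40000 nM and 200000 nM, with a fair chance that only a limit is reported.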

Compound 4, half-maximal inhibitory concentration: > 100000 nM
Compound 4 ended at the assay's limit; the forecaster's own chance of this, stated with the estimate: 45%; at least 1.1-fold (0.04 log units) between middle value and limit.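

The change from methoxy to methyl cannot be read at this position, because compound 3 and compound 4 both stop at a limit rather than a number: the limit of > 100000 nM in this assay, at which 2 of the 4 values shown sit.

The 4-methylphenyl group in place of 3-chloro-4-fluorophenyl gives an at least 5.4-fold higher number from compound 2 to compound 4 (0.73 log units; beyond the scatter). Hydrogen in place of one methyl of the 3,4-dimethylphenyl group gives an at least 1.4-fold higher number from compound 1 to compound 4 (0.17 log units; that floor lies within the scatter), so the true size of that step remains unknown.

From the compounds shown here alone, whether an amine or a hydroxyl group on this carbon would bring a measurable number stays open.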